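Compound 1 Gains a 5-methoxypyridin-2-yl Group

This account rests on a few compounds, and the source may have more. Where it says the series, first, only, none or still open, it means among the compounds named here.

In a physicochemical assay for solubility, in phosphate buffer, with a stated time of 24 h, at pH 7.4 (on this read-out lower numbers stand for lower solubility and higher numbers for higher solubility), compound 1 (`Cc1oc(C(=O)NS(=O)(=O)c2ccccc2)cc1COc1ccc(-c2ccccc2)cc1`) gives 2 ug/mL as the lowest of the three numbers measured. Compound 2 (`CCCS(=O)(=O)NC(=O)c1cc(COc2ccc(-c3ccc(OC)cc3)cc2)c(C)o1`) gives 7 ug/mL and compound 3 (`COc1ccc(-c2ccc(OCc3cc(C(=O)NS(=O)(=O)c4c(C)noc4C)oc3C)cc2)c(C)c1`) gives 200 ug/mL with both numbers higher than that of compound 1 and beyond the scatter. Compound 4 (`COc1ccc(-c2ccc(OCc3cc(C(=O)NS(=O)(=O)c4ccccc4)oc3C)cc2)nc1`) awaits measurement. Relative to compound 1 it carries 5-methoxypyridin-2-yl in place of phenyl on an aromatic carbon, para to a large group (5-methoxypyridin-2-yl in place of phenyl on an aromatic carbon). For the measured compounds named here, no measured pair shows this change alone, so the expectation in this assay is only a moderate rise beyond the scatter, guided by compound 2 at 7 ug/mL as the nearest measured number. The expected step is a 7.5-fold higher number from compound 1 to compound 4 (0.88 log units; beyond the scatter) and it points upward. Compound 4 is estimated at 15 ug/mL with an expected range from 4 ug/mL to 60 ug/mL on this read-out.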

Compound 4, solubility: 30 ug/mL
Compound 4: middle estimate off by 2.0-fold (0.30 log units), on the low side; the measured number falls inside the stated range.
By their numbers in this assay, from the lowest: compound 1; then compound 2; then compound 4; then compound 3.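

In this assay, for the compounds shown here, the replacement of phenyl by 5-methoxypyridin-2-yl on an aromatic carbon, para to a large group, gives a 15-fold higher number from compound 1 to compound 4 (1.18 log units; beyond the scatter) as the first step here read with only one place changed. This shows that the read-out responds strongly to this change at this position while the rest of the core of compound 1 stays the same. Nothing measured here speaks to the reason for the step.

Still open, as far as these compounds go, is how a plain pyridinyl group or a methoxyphenyl group at this position would compare. The compounds shown therefore leave unresolved whether the step goes with the ring nitrogen, the methoxy group or both together.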